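A few compounds are considered here, and "the series" means these few. Any claim that something is new, unique, unknown or untested is made for them only; others in the source may bear on it.

Of the compounds shown here, three that share one core have been measured so far. Compound 1 `COC(=O)c1cc(-c2csc(N/N=C/c3cccs3)n2)ccc1OCc1ccccc1` carries a thiophen-2-yl group on the carbon that is double-bonded to nitrogen; compound 2 `Cc1ccc(-c2csc(N/N=C/c3ccc(Cl)cc3Cl)n2)cc1` carries a 2,4-dichlorophenyl group at the same place on a different left-hand part; compound 3 `Fc1ccc(-c2csc(N/N=C/c3cccs3)n2)cc1` again carries thiophen-2-yl. In a functional assay, read by spectrophotometry, with a stated time of 15 min, tested at 100 ug/mL (a lower number here means a weaker effect, a higher number a stronger effect of the compound at the concentration tested), compound 1 gives 96.3%, compound 2 gives 95.1% and compound 3 gives 97%. The number of compound 1 stands between the other two, and both gaps lie within the usual scatter of this assay, so the three compounds cannot be told apart on these numbers.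

Compound 4 `COC(=O)c1cc(-c2csc(N/N=C/c3ccc(Cl)cc3Cl)n2)ccc1OCc1ccccc1` has not yet been measured. It differs from compound 1 in one place: 2,4-dichlorophenyl in place of thiophen-2-yl on a carbon with a double bond to nitrogen. The left-hand part of compound 1 is kept. For the measured compounds named here, no step between two measured compounds isolates this change, but the same exchange appears when compound 2 and compound 3 are set side by side, and their values show no difference beyond the scatter. The step from compound 1 to compound 4 in this assay is therefore expected to be small, with no direction beyond the scatter, a number 0.8 percentage points lower from compound 1 to compound 4 (within the scatter). Compound 4 is estimated to give 95.5%, within a range from 89% to 99%.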

Compound 4, a percentage reported as inhibition, at one concentration (the size of the read-out at that concentration, not a potency): 56.1%
Compound 4: the middle estimate sits 39.4 percentage points above what was measured; the measured number lies below the stated range.
By their numbers in this assay, from the lowest: compound 4; then compounds 2, 1 and 3 (each within the scatter of the next).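

In this assay, exchanging the thiophen-2-yl group for 2,4-dichlorophenyl gives a number 40.2 percentage points lower from compound 1 to compound 4 (beyond the scatter) and so shows that, with the left-hand part of compound 1 kept, this place is far from indifferent to the group it carries. The earlier compounds gave no hint of this, and the group alone does not account for the low number: compound 2 holds the same 2,4-dichlorophenyl on another left-hand part and gives 95.1% while compound 4 gives 56.1% in the same assay, so the loss appears only when this group meets the left-hand part of compound 1. No measurement shown here gives a reason for this loss.

Still open, on these data alone, is whether a plain phenyl, a phenyl carrying a single chlorine or an amine at this place would keep the high number of compound 1 or share the low number of compound 4. As far as these compounds go, it is also open which piece of the left-hand part, the methyl ester or the benzyloxy group, matters for the loss.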